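The source may report more compounds than this note shows. Statements on the series, on what has been measured and on what is new or still open speak of the compounds shown alone.

Compound 1 `CCOCc1nnc(N2C[C@@H]3C[C@]3(c3ccc(F)cc3Cl)C2)n1-c1ccc(OC)nc1`: 9.3 nM
Compound 2 `COc1ccc(-n2c(COCCF)nnc2N2C[C@@H]3C[C@]3(c3ccc(F)cc3Cl)C2)cn1`: 44 nM

In a functional assay on HEK293 cells for antagonist activity at Oxytocin receptor (Homo sapiens), read by calcium flux, with a stated time of 10 min, in the presence of a further agent that is not named here (a lower number here means a stronger inhibitor, a higher number a weaker inhibitor), compound 2 gives 44 nM, the highest of the two numbers measured; its nearest neighbour, compound 1, gives 9.3 nM. Compound 3 `COc1ccc(-n2c(COC3CCOCC3)nnc2N2C[C@@H]3C[C@]3(c3ccc(F)cc3Cl)C2)cn1` carries oxan-4-yl in place of 2-fluoroethyl on an oxygen on a saturated carbon. For the measured compounds named here, no measured step covers this replacement; the only step at this position, a 4.7-fold higher number from compound 1 to compound 2 (0.67 log units; beyond the scatter), changed a different part of the chain. Compound 3 is therefore expected to show a step of a 1.5-fold lower number from compound 2 to compound 3 (0.17 log units; within the scatter) in this assay, not clearly beyond the scatter. The estimate for compound 3 is 30 nM, within 8 nM to 120 nM.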

Compound 3, half-maximal inhibitory concentration: 826 nM
Compound 3: the middle estimate sits 28-fold (1.44 log units) below what was measured; the measured number lies above the stated range.
By their numbers in this assay, from the lowest: compound 1; then compound 2; then compound 3.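

In this assay, oxan-4-yl on the oxygen gives a 19-fold higher number from compound 2 to compound 3 (1.27 log units; beyond the scatter), and measured against ethyl it gives an 89-fold higher number from compound 1 to compound 3 (1.95 log units; beyond the scatter). This position, where 2-fluoroethyl brought only a modest step, therefore does not treat all groups on this oxygen alike: of the three, ethyl gives the lowest number and oxan-4-yl the highest. Nothing available here accounts for this large step.

The compounds shown leave open whether the ring or simply the larger group drives the step. A propyl chain, a cyclopropyl ring or an oxetan-3-yl ring on the same oxygen could separate the two.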